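The source may hold more compounds than are shown below. What is called first, only, known or untested is meant among the compounds shown, and "the series" means these compounds.

Compound 1 `CC(C)c1ncncc1-c1nc2cc(F)c(F)cc2n1C1CC1` and compound 2 `Fc1cc2nc(-c3cncnc3C(F)F)n(C3CC3)c2cc1F` have both been measured in an assay on cells for inhibition of cytochrome P450 11B2, mitochondrial (Homo sapiens), read by HPLC, with a stated time of 90 min; a higher number here means a weaker inhibitor, a lower number a stronger inhibitor: compound 1 gives 5 nM and compound 2 gives 18 nM.

Compound 2 thus stands highest of the two numbers, and its nearest neighbour is compound 1, reached through the step of a 3.6-fold higher number from compound 1 to compound 2 (0.56 log units; beyond the scatter). Compound 3 `Fc1cc2nc(-c3cncnc3C(F)(F)F)n(C3CC3)c2cc1F` differs from compound 2 by fluoro in place of hydrogen on a saturated chain carbon bound to an aromatic carbon and two fluorine atoms. Among the measured compounds shown here, the single measured step, a 3.6-fold higher number from compound 1 to compound 2 (0.56 log units; beyond the scatter), concerns the same group but a different exchange, so it bears only loosely on this one; a small step in this assay, if any beyond the scatter, is expected. Compound 3 is therefore estimated at 25 nM, within 10 nM to 60 nM. The expected step is a 1.4-fold higher number from compound 2 to compound 3 (0.14 log units; within the scatter).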

Compound 3, half-maximal inhibitory concentration: 25 nM
The estimate for compound 3 equals the measured number at the digits printed; the range from low to high includes it.
By their numbers in this assay, from the lowest: compound 1; then compounds 2 and 3 (each within the scatter of the next).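

In this assay, difluoromethyl to trifluoromethyl is a step of a 1.4-fold higher number from compound 2 to compound 3 (0.14 log units; within the scatter) and so adds no difference that these numbers can resolve. The wider exchange, from isopropyl to trifluoromethyl, is a step of a 5.0-fold higher number from compound 1 to compound 3 (0.70 log units; beyond the scatter) and goes the same way as the step from isopropyl to difluoromethyl, so both fluorinated groups stand apart from isopropyl. Nothing measured here accounts for either step. As far as these compounds go, whether a methoxy or cyclopropyl group on this aromatic carbon would read with isopropyl or with the fluorinated groups stays open.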